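The compounds below may be only part of what the source reports. "The series", "measured", "known", "first", "only" and "open" are said of these compounds alone.

Measured compounds in an assay for inhibition of hexokinase-2 (Homo sapiens), read by coupled enzyme assay, with a stated time of 10 min, in the presence of a further agent that is not named here; on this read-out lower numbers stand for stronger inhibition and higher numbers for weaker inhibition:
Compound 1 `C=C1CC[C@H]2[C@@](C)(CCC(=O)N[C@@]2(C)COC(=O)c2cccnc2)[C@@H]1/C=C/C1=CCOC1=O` gives a value that is a limit of the assay, > 50000 nM.
Compound 2 `C=C1CC[C@H]2[C@@](C)(CCC(=O)N[C@@]2(C)COC(=O)c2ccccc2)[C@@H]1/C=C/C1=CCOC1=O` gives a value that is a limit of the assay, > 50000 nM.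
Compound 3 `C=C1CC[C@H]2[C@@](C)(CC[C@@H](OC(=O)c3cccnc3)[C@@]2(C)NC=O)[C@@H]1/C=C/C1=CCOC1=O` gives a value that is a limit of the assay, > 50000 nM.

All three values sit at the limit of > 50000 nM in this assay, at which 3 of the 3 values shown sit, so none of the three compounds shows measurable inhibition here. Compound 1 and compound 2 differ by one change, (phenyl in place of pyridin-3-yl on a carbonyl carbon). The step that the two limits leave unreadable from compound 1 to compound 2 has limits at both ends, so its size is not readable. Compound 3 has the same atoms as compound 1 joined differently; the difference between the two cores is not broken down here.

Compound 4 `C=C1CC[C@H]2[C@@](C)(CC[C@@H](OC(=O)c3ccccc3)[C@@]2(C)NC=O)[C@@H]1/C=C/C1=CCOC1=O` has not yet been measured. It differs from compound 3 by phenyl in place of pyridin-3-yl on a carbonyl carbon, the same change as from compound 1 to compound 2, at the same place. For compound 4 the expected step in this assay is a step that the limit leaves unreadable from compound 3 to compound 4. That expectation rests on compound 1 and compound 2 both sitting at the limit of > 50000 nM in this assay, at which 3 of the 3 values shown sit, and on compound 3 sitting there too. Compound 4 is estimated at 80000 nM, between 30000 nM and 300000 nM, most likely reported only as a limit.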

Compound 4, half-maximal inhibitory concentration: > 50000 nM
Compound 4: only a limit was reported; the forecaster's own chance of this, stated with the estimate: 85%; the middle value does not contradict the limit.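

In this assay compound 4 gives > 50000 nM, which is a limit of the assay. No step can be read from compound 3 to compound 4, as both ends are limits: the limit of > 50000 nM in this assay, at which 4 of the 4 values shown sit. The compounds shown leave open how strongly any of them inhibits in this assay, and whether phenyl or pyridin-3-yl on the carbonyl carbon makes any difference there.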